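Methyl added to two cores: one readable value to build on

The source may hold more compounds than are shown below. What is called first, only, known or untested is meant among the compounds shown, and "the series" means these compounds.

The study centres on a functional assay on the whole organism (strain Sprague-Dawley) for inhibition, with Rattus norvegicus as the target; a higher number here means that more compound is needed for the effect, a lower number that less compound is needed. Compound 1 `O=c1c(-c2nn[nH]n2)c[nH]c2ccccc12` sits at a limit of the assay, giving > 20 mg/kg in this assay. Compound 2 `Cc1cccc2c(=O)c(-c3nn[nH]n3)c[nH]c12` also sits at a limit, giving > 10 mg/kg in this assay. Between them lies (methyl in place of hydrogen on an aromatic carbon), and it made a step that the two limits leave unreadable from compound 1 to compound 2. For the measured compounds named here, compound 3 `c1ccc2ncc(-c3nn[nH]n3)cc2c1` gives 25 mg/kg in this assay, the only number among the three values; the difference between its core and that of compound 1 is not broken down here. Compound 4 `Cc1cccc2cc(-c3nn[nH]n3)cnc12` is not yet measured and differs from compound 3 by methyl in place of hydrogen on an aromatic carbon, the same change as from compound 1 to compound 2. Since that earlier step is unreadable, the expectation rests on compound 3 giving 25 mg/kg, and compound 4 is expected to show no change at the digits printed from compound 3 to compound 4 (within the scatter), within the usual scatter. Compound 4 is therefore estimated at 25 mg/kg, with a range from 8 mg/kg to 80 mg/kg.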

Compound 4, minimum effective dose: 25 mg/kg
The estimate for compound 4 equals the measured number at the digits printed; the range from low to high includes it.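

On the core of compound 3, methyl in place of hydrogen on an aromatic carbon gave no change at the digits printed from compound 3 to compound 4 (within the scatter) in this assay for this pair. The same change on the core of compound 1 cannot be read, with both of its ends sitting at limits of the assay. The series therefore offers one readable case, which does not show that the change behaves alike on both cores.

The compounds shown leave open whether an amine, a carboxylic acid or a longer chain on that aromatic carbon would shift the dose needed in this assay on either core. No measurement shown bears on the reason for the result.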